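Isoquinolinyl amide as a follow-up to two aroyl analogues

The compounds below may be only part of what the source reports. "The series", "measured", "known", "first", "only" and "open" are said of these compounds alone.

Compound 2 `C[C@H](c1ccc(F)cc1)N(Cc1cccc(C(=O)O)c1)C(=O)c1cc2ccccc2nn1` gives 340 nM in an assay on CHO T-rex cells for antagonist activity at transient receptor potential cation channel subfamily M member 8 (Homo sapiens), read by calcium flux, with a stated time of 20 min (a lower number here means a stronger inhibitor, a higher number a weaker inhibitor), the highest of the two numbers recorded so far; its nearest neighbour, compound 1 `C[C@H](c1ccc(F)cc1)N(Cc1cccc(C(=O)O)c1)C(=O)c1cc2ccccc2s1`, gives 145 nM in the same assay. Within the data shown here, the only measured step between them, a 2.3-fold higher number from compound 1 to compound 2 (0.37 log units; beyond the scatter), was modest but beyond the scatter. Compound 3 `C[C@H](c1ccc(F)cc1)N(Cc1cccc(C(=O)O)c1)C(=O)c1cc2ccccc2cn1` has not yet been measured in this assay. It differs from compound 2 in that (a group of 10 heavy atoms (9 carbon, 1 nitrogen; one six-membered aromatic ring of carbon only, one six-membered aromatic ring with 1 hetero atom) in place of a group of 10 heavy atoms (8 carbon, 2 nitrogen; one six-membered aromatic ring of carbon only, one six-membered aromatic ring with 2 hetero atoms), on a carbonyl carbon). Among the measured compounds shown here, the one measured step bears only loosely on this change, since compound 1 carries a different ring system altogether; still, the group that enters shares the six-membered shape of both neighbours. The expectation for compound 3 is therefore a number between those of its two relatives, with a change from compound 2 of about a 1.7-fold lower number from compound 2 to compound 3 (0.23 log units; within the scatter), which may not exceed the scatter. The estimate for compound 3 is 200 nM, between 80 nM and 500 nM.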

Compound 3, half-maximal inhibitory concentration: 90 nM
Compound 3: the middle estimate sits 2.2-fold (0.35 log units) above what was measured; measured number inside the range.
By their numbers in this assay, from the lowest: compounds 3 and 1 (each within the scatter of the next); then compound 2.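

Within the six-membered partners on the carbonyl carbon, the exact ring make-up matters: in this assay, isoquinolin-3-yl, which has one ring nitrogen where the group it replaces has two, gives a 3.8-fold lower number from compound 2 to compound 3 (0.58 log units; beyond the scatter) and thus a step beyond the scatter at equal heavy-atom count. The other comparison, a 1.6-fold lower number from compound 1 to compound 3 (0.21 log units; within the scatter), stays within the scatter, so isoquinolin-3-yl and 1-benzothiophen-2-yl cannot be ordered here, although one ring is six-membered with nitrogen and the other five-membered with sulfur. Nothing available explains the size of either step.

The compounds shown leave open whether the ring nitrogen's location matters, as isoquinolin-1-yl or quinolin-2-yl would test. They also leave open whether the fused carbon ring is needed, as pyridin-2-yl would test.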